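The source may report more compounds than this note shows. Statements on the series, on what has been measured and on what is new or still open speak of the compounds shown alone.

- Compound 1 `CCOC(=O)C1=C(N/N=C(/C(=O)Br)c2ccc(Br)cc2)Nc2[nH]nc(C)c2C1c1ccc(N(C)C)cc1`: 65000 nM
- Compound 2 `CCOC(=O)C1=C(N)Nc2[nH]nc(C)c2C1c1ccc(N(C)C)cc1`: 4240 nM

In a functional assay on HepG2 cells (Homo sapiens) for inhibition, read by MTT assay, with a stated time of 48 h (on this read-out higher numbers stand for weaker inhibition and lower numbers for stronger inhibition), compound 2 gives 4240 nM, the lower of the two numbers and so the stronger inhibition. Compound 3 `CCOC(=O)C1=C(N/N=C(/C(=O)Br)c2ccc(Cl)cc2)Nc2[nH]nc(C)c2C1c1ccc(N(C)C)cc1` has not yet been measured. Starting from compound 2, the structural change is a group of 12 heavy atoms (8 carbon, 1 nitrogen, 1 oxygen, 1 chlorine, 1 bromine; one six-membered aromatic ring of carbon only) in place of a hydrogen atom, on an amine nitrogen.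

For the measured compounds named here, one measured step bears on this change: a 15-fold lower number from compound 1 to compound 2 (1.19 log units; beyond the scatter). That large step runs in the opposite direction, removing a group rather than adding one. The group removed there differs from the one entering here only in carrying bromine where the new group carries chlorine. As far as these compounds go, the data contain no measured swap of bromine for chlorine, so the size of that difference remains unknown, and it widens the range of the estimate.

Reversing the measured step suggests a large rise in the number, meaning weaker inhibition, to a level near compound 1 at 65000 nM. The expected change is a 13-fold higher number from compound 2 to compound 3 (1.11 log units; beyond the scatter). For compound 3, the estimated value is 55000 nM, with an expected range of 20000 nM to 130000 nM.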

Compound 3, half-maximal inhibitory concentration: 50300 nM
Estimate against measurement, compound 3: 1.1-fold (0.04 log units) above; low and high end bracket the measured number.
By their numbers in this assay, from the lowest: compound 2; then compounds 3 and 1 (each within the scatter of the next).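

In this assay, the amine nitrogen of compound 2 now has a second large substituent to compare, and a 12-fold higher number from compound 2 to compound 3 (1.07 log units; beyond the scatter) shows that this one also goes with much weaker inhibition than the free amine, so the large loss seen earlier was not unique to the bromo-bearing group. Chloro in place of bromo on an aromatic carbon gives a 1.3-fold lower number from compound 1 to compound 3 (0.11 log units; within the scatter) and so, at this level of scatter, the assay does not tell the two halogens apart on this group, although both compounds sit in a range where inhibition is already weak. Nothing measured here explains why the large group goes with weaker inhibition.

The compounds shown leave open how much of this large group goes with the loss, for instance whether a simple acetyl group or a short alkyl chain on the amine nitrogen would stay close to compound 2 or fall towards compound 3. As far as these compounds go, it also remains open whether a methoxy group or plain hydrogen in place of the halogen on the aromatic ring would leave the number unchanged.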